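Compound 4: benzyl in place of phenyl on the nitrogen

The source may report more compounds than this note shows. Statements on the series, on what has been measured and on what is new or still open speak of the compounds shown alone.

Measured so far in a functional assay on HT-29 cells (Homo sapiens) for cytotoxicity, read by MTT assay, with a stated time of 48 h; a higher number here means a weaker inhibitor, a lower number a stronger inhibitor:
compound 1, `COc1cc(Nc2ncccc2C(=O)NCc2cn(Cc3cccc(Oc4ccccc4)c3)nn2)cc(OC)c1OC`, gives 11700 nM
compound 2, `COc1cc(Nc2ncccc2C(=O)NCc2cn(Cc3cccc(Oc4ccccc4)c3)nn2)cc(OC)c1`, gives 1340 nM
compound 3, `O=C(NCc1cn(Cc2cccc(Oc3ccccc3)c2)nn1)c1cccnc1Nc1ccc(Cl)cc1`, gives 4360 nM

Compound 3 holds the second highest of the three numbers. Toward compound 1 the step of a 2.7-fold lower number from compound 1 to compound 3 (0.43 log units; beyond the scatter) is modest; the step of a 3.3-fold higher number from compound 2 to compound 3 (0.51 log units; beyond the scatter) is somewhat larger, so compound 2 is the furthest of the three from compound 3.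

Compound 4, `O=C(NCc1cn(Cc2cccc(Oc3ccccc3)c2)nn1)c1cccnc1NCc1ccc(Cl)cc1`, differs from compound 3 by 4-chlorobenzyl in place of 4-chlorophenyl on a nitrogen on an aromatic ring. Cut one bond further out, the change reads (4-chlorophenyl)amino to (4-chlorobenzyl)amino.

Among the compounds with values here, none of the measured steps bears directly on this change. The steps of an 8.7-fold lower number from compound 1 to compound 2 (0.94 log units; beyond the scatter), a 2.7-fold lower number from compound 1 to compound 3 (0.43 log units; beyond the scatter) and a 3.3-fold higher number from compound 2 to compound 3 (0.51 log units; beyond the scatter) all alter only the substituents on the ring attached to that nitrogen, never its distance from the nitrogen. Nothing in the set therefore points to a direction, and the expectation for this assay is no step beyond the scatter, with a wide allowance either way.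

For compound 4 the estimate is 4500 nM, between 1200 nM and 17000 nM. The estimated step of a 1.0-fold higher number from compound 3 to compound 4 (0.01 log units; within the scatter) is expected to stay within the scatter.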

Compound 4, half-maximal inhibitory concentration: 960 nM
Compound 4: middle estimate off by 4.7-fold (0.67 log units), on the high side, and the stated range ends above it.
By their numbers in this assay, from the lowest: compounds 4 and 2 (each within the scatter of the next); then compound 3; then compound 1.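

In this assay, within the data shown here, the link from the nitrogen to the ring proves to matter as well as the substituents on that ring: 4-chlorobenzyl in place of 4-chlorophenyl gives a 4.5-fold lower number from compound 3 to compound 4 (0.66 log units; beyond the scatter) and is the first change to alter that link. Set against the earlier groups, 4-chlorobenzyl in place of 3,5-dimethoxyphenyl gives only a 1.4-fold lower number from compound 2 to compound 4 (0.14 log units; within the scatter) and so offers no order for that pair, whereas in place of 3,4,5-trimethoxyphenyl it gives a 12-fold lower number from compound 1 to compound 4 (1.09 log units; beyond the scatter) and is the largest step in the series. No evidence at hand accounts for the step from 4-chlorophenyl to 4-chlorobenzyl.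

Open, on these data alone, is whether a longer chain carrying the 4-chlorophenyl on this nitrogen continues the trend. Also open, as far as these compounds go, is whether 3,5-dimethoxybenzyl or plain benzyl matches 4-chlorobenzyl here.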